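Dropping the Chloro from a Hydrazone Growth Inhibitor

The source may hold more compounds than are shown below. What is called first, only, known or untested is meant among the compounds shown, and "the series" means these compounds.

Two compounds sharing a common fragment were compared in a functional assay on HCT-116 cells (Homo sapiens) for antiproliferative activity, read by sulforhodamine B assay, with a stated time of 48 h; a lower number here means a stronger inhibitor of growth, a higher number a weaker inhibitor of growth. Compound 1 `COc1ccc(OC)c(/C=C/c2nnc(Nc3ccc(Cl)cc3)o2)c1` presents that fragment on one core, and in this assay compound 1 gives 2970 nM. Compound 2 `COc1ccc(OC)c(/C=C/C(=O)N/N=C/c2ccc(Cl)cc2)c1` presents it on a different core ending in a 4-chlorophenyl group, and in this assay compound 2 gives 75 nM. Going by the values given here, of the two numbers available, that of compound 2 is the lower; the only other number, from compound 1, lies far above it, a gap well beyond the usual scatter, so compound 2 is the stronger growth inhibitor of the pair.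

Compound 3 `COc1ccc(OC)c(/C=C/C(=O)N/N=C/c2ccccc2)c1` is the next compound, and it differs from compound 2 by hydrogen in place of chloro on an aromatic carbon. Among the compounds with values here, no measured pair differs in this way, so the size of the step is a matter of expectation only. The author expects the step of a 2.0-fold higher number from compound 2 to compound 3 (0.30 log units; within the scatter) to be small, in the direction of weaker growth inhibition, and possibly not beyond the scatter. Compound 3 is therefore estimated at 150 nM, with a range from 50 nM to 500 nM.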

Compound 3, concentration for 50% growth inhibition: 2640 nM
Estimate against measurement, compound 3: 18-fold (1.25 log units) below; measured number above the stated range.
By their numbers in this assay, from the lowest: compound 2; then compounds 3 and 1 (each within the scatter of the next).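

In this assay, the change from 4-chlorophenyl to phenyl gives a 35-fold higher number from compound 2 to compound 3 (1.55 log units; beyond the scatter), a large step well beyond the scatter, so this place on the aromatic ring, para to a large group, is far from indifferent to what it carries. The earlier compounds could not show this, as compound 1 and compound 2 differ in their cores and neither comparison isolated the chloro; here, a single heavy atom accounts for most of the growth inhibition seen with compound 2. Nothing available here gives a measured reason for a step of this size from so small a change.

On these data alone, it remains open whether the strength of compound 2 belongs to chloro specifically, or whether fluoro, bromo, a methoxy group or an amine at the same place would hold it as well. The compounds shown also leave open whether taking the chloro off compound 1 would cost as much on that core, so the step cannot yet be carried beyond this one pair.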